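Cyclopropylmethyl to benzyl: the next step for compound 4

The source may report more compounds than this note shows. Statements on the series, on what has been measured and on what is new or still open speak of the compounds shown alone.

In a functional assay on HCT-116 cells (Homo sapiens) for cytotoxicity, read by MTT assay, with a stated time of 48 h (on this read-out higher numbers stand for weaker inhibition of growth and lower numbers for stronger inhibition of growth), compound 1 `CC(C)n1c(C(F)(F)F)nc2cc(Cl)c(Cl)cc21` gives 81900 nM, compound 2 `C=CCn1c(C(F)(F)F)nc2cc(Cl)c(Cl)cc21` gives 89200 nM and compound 3 `FC(F)(F)c1nc2cc(Cl)c(Cl)cc2n1CC1CC1` gives 61300 nM, so compound 3 stands within the usual scatter of the other two. Compound 4 `FC(F)(F)c1nc2cc(Cl)c(Cl)cc2n1Cc1ccccc1` has phenyl in place of cyclopropyl on a saturated chain carbon bound to an aromatic nitrogen. The measured steps at this same place are small: a 1.1-fold higher number from compound 1 to compound 2 (0.04 log units; within the scatter), a 1.3-fold lower number from compound 1 to compound 3 (0.13 log units; within the scatter) and a 1.5-fold lower number from compound 2 to compound 3 (0.16 log units; within the scatter), all within the scatter. Within the data shown here, none of the measured compounds carries an aromatic ring there, so this expectation is uncertain. In this assay no step beyond the scatter is expected, and the estimated one is a 1.1-fold lower number from compound 3 to compound 4 (0.05 log units; within the scatter). For compound 4 the estimated value is 55000 nM, with an expected range of 22000 nM to 110000 nM.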

Compound 4, concentration for 50% growth inhibition: 8600 nM
The estimate for compound 4 lay 6.4-fold (0.81 log units) above the measured number; the whole stated range lies above it.
By their numbers in this assay, from the lowest: compound 4; then compounds 3, 1 and 2 (each within the scatter of the next).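

Benzyl on the aromatic nitrogen gives a 7.1-fold lower number from compound 3 to compound 4 (0.85 log units; beyond the scatter) and a 10-fold lower number from compound 2 to compound 4 (1.02 log units; beyond the scatter) and a 9.5-fold lower number from compound 1 to compound 4 (0.98 log units; beyond the scatter) in this assay while isopropyl, allyl and cyclopropylmethyl stay within the scatter of one another. Among these compounds, this position is therefore not indifferent to its group, as the earlier compounds alone suggested, and of these four only compound 4, the one with an aromatic ring there, stands apart. Still open, as far as these compounds go, is how a substituted benzyl, such as methoxybenzyl, or a longer phenethyl chain would compare. No evidence here explains the step.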